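Swapping a Pyridine Arm for a Methylpiperidine

A few compounds are considered here, and "the series" means these few. Any claim that something is new, unique, unknown or untested is made for them only; others in the source may bear on it.

Compound 1 `FC(F)(F)c1ccc(CNc2nc(-c3ccccc3C(F)(F)F)nc3ccccc23)cc1`: 8900 nM
Compound 2 `Cc1cnc(-c2ccccc2C(C)C)nc1NCc1cccnc1`: 1300 nM

In an assay on a protein complex for inhibition of ubiquitin carboxyl-terminal hydrolase 1/WD repeat-containing protein 48 (Homo sapiens), read by fluorescence (a lower number here means a stronger inhibitor, a higher number a weaker inhibitor), compound 1 gives 8900 nM, while compound 2 gives 1300 nM, the lowest of the two numbers and beyond the scatter from compound 1. Compound 3 `Cc1cnc(-c2ccccc2C(C)C)nc1NCC1CCN(C)CC1` differs from compound 2 in one place: 1-methylpiperidin-4-yl in place of pyridin-3-yl on a saturated chain carbon bound to a nitrogen on an aromatic ring. Among the measured compounds shown here, no measured pair shows this change, so its effect is unknown. A small step toward a weaker inhibitor, near the edge of the scatter, is expected: a 1.9-fold higher number from compound 2 to compound 3 (0.28 log units; within the scatter). Compound 3 is therefore estimated at 2500 nM, with a range from 600 nM to 10000 nM.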

Compound 3, half-maximal inhibitory concentration: "not active" (no number reported)
Compound 3: no number reported; there is nothing to compare the estimate with.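

Among the compounds shown here, compound 3 is reported as not active, without a number, so no step from compound 2 to compound 3 can be read. On these data alone, how far 1-methylpiperidin-4-yl in place of pyridin-3-yl moves the number stays open. Nothing measured here explains this result.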